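A few compounds are considered here, and "the series" means these few. Any claim that something is new, unique, unknown or untested is made for them only; others in the source may bear on it.

Values in a functional assay on MCF7 cells (Homo sapiens) for cytotoxicity, read by MTT assay, with a stated time of 72 h (a higher number here means a weaker inhibitor, a lower number a stronger inhibitor), for the measured members of the series:

compound 1, `Cc1cc(=O)n(-c2ccccc2OC(F)(F)F)nc1C(=O)Nc1ccc(Oc2ncnc3sccc23)cc1`, compound 1 gives 11000 nM
compound 2, `Cc1cc(=O)n(-c2cccc(F)c2)nc1C(=O)Nc1ccc(Oc2ncnc3sccc23)cc1`, compound 2 gives 27200 nM
compound 3, `Cc1cc(=O)n(-c2ccccc2OC(F)(F)F)nc1C(=O)Nc1ccc(Oc2ncnc3sccc23)c(F)c1`, for compound 3 only a limit is recorded, > 40000 nM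

Compound 2 differs from compound 1 by 3-fluorophenyl in place of 2-(trifluoromethoxy)phenyl on an aromatic nitrogen. The step is a 2.5-fold higher number from compound 1 to compound 2 (0.39 log units; beyond the scatter). Compound 3 differs from compound 1 by fluoro in place of hydrogen on an aromatic carbon, and the step is an at least 3.6-fold higher number from compound 1 to compound 3 (0.56 log units; beyond the scatter); its size cannot be fixed further because compound 3 sits at the limit of > 40000 nM in this assay, at which 1 of the 3 values shown sits.

Compound 4, `Cc1cc(=O)n(-c2cccc(F)c2)nc1C(=O)Nc1ccc(Oc2ncnc3sccc23)c(F)c1`, is not yet measured. It differs from compound 3 by 3-fluorophenyl in place of 2-(trifluoromethoxy)phenyl on an aromatic nitrogen. The place line reads the same as for the change from compound 1 to compound 2, so this is the same change made on the core of compound 3 rather than on the core of compound 1, the two cores differing as described above. For the measured compounds named here, the only precedent for this change is the step from compound 1 to compound 2, which weakened inhibition modestly. Carried over to compound 3, which already sits at the limit, the expected outcome for compound 4 is a step that the limit leaves unreadable from compound 3 to compound 4, and it is expected that this assay will again report only a limit rather than a number. The estimate for compound 4 is 80000 nM, with an expected range from 40000 nM to 200000 nM.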

Compound 4, half-maximal inhibitory concentration: 17300 nM
Compound 4: middle estimate off by 4.6-fold (0.67 log units), on the high side, and the stated range ends above it.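

In this assay, 3-fluorophenyl in place of 2-(trifluoromethoxy)phenyl gives an at least 2.3-fold lower number from compound 3 to compound 4 (0.36 log units; beyond the scatter), so the change does not keep its direction when carried from the core of compound 1 to the core of compound 3: the same change on two cores in this assay, a 2.5-fold higher number (0.39 log units; beyond the scatter) from compound 1 to compound 2 and an at least 2.3-fold lower number (0.36 log units; beyond the scatter) from compound 3 to compound 4, at least 5.7-fold (0.75 log units) apart, beyond the scatter of two such steps

Fluoro in place of hydrogen on an aromatic carbon likewise depends on the group on the aromatic nitrogen, giving a 1.6-fold lower number from compound 2 to compound 4 (0.20 log units; within the scatter), a step that differs from the one seen when the same change is made on compound 1: the same change on two cores in this assay, an at least 3.6-fold higher number (0.56 log units; beyond the scatter) from compound 1 to compound 3 and a 1.6-fold lower number (0.20 log units; within the scatter) from compound 2 to compound 4, at least 5.7-fold (0.75 log units) apart, beyond the scatter of two such steps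

Compound 3 is recorded only as a limit, > 40000 nM, so these comparisons fix the direction of the step to compound 4 and only a minimum for its size, and this single set of four compounds gives neither a cause nor a rule for other cores.

The compounds shown leave open whether the dependence between the two sites holds for other groups, such as an unsubstituted phenyl on the aromatic nitrogen or a chloro in place of the fluoro on the aromatic carbon. They also leave open which part of the exchange matters, since 3-fluorophenyl and 2-(trifluoromethoxy)phenyl differ in both the group carried and its place on the phenyl ring.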